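The source may hold more compounds than are shown below. What is called first, only, known or untested is meant among the compounds shown, and "the series" means these compounds.

Measured compounds:
- compound 1, `Cc1cc(Nc2nc(NCc3cc(F)ccc3F)nc3ccccc23)n[nH]1`: 7.5 nM
- compound 2, `Cc1cc(Nc2nc(NCc3ccc(F)cc3F)nc3cc(Cl)ccc23)n[nH]1`: 15 nM
- compound 3, `Fc1ccc(CNc2nc(Nc3cc(C4CC4)[nH]n3)c3ccc(Cl)cc3n2)c(F)c1`: 290 nM

All three compounds were tested in an assay for inhibition of high affinity nerve growth factor receptor (Homo sapiens), read by HTRF, with a stated time of 30 min, in the presence of a further agent that is not named here; on this read-out lower numbers stand for stronger inhibition and higher numbers for weaker inhibition. Compound 3 stands at the highest of the three numbers, so it is the weakest inhibitor among them; compound 2 is nearest to it, and compound 1 is furthest away. Within the data shown here, the one single-change step among the measured compounds runs from compound 2 to compound 3 and gave a 19-fold higher number from compound 2 to compound 3 (1.29 log units; beyond the scatter), a swap of cyclopropyl for methyl on an aromatic carbon.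

Compound 4, `Fc1ccc(CNc2nc(Nc3cc(C4CC4)[nH]n3)c3ccc(Br)cc3n2)c(F)c1`, is not yet measured. It differs from compound 3 in one place: bromo in place of chloro on an aromatic carbon. No measured step involves a change of this kind; the only step shown concerns a different group at a different position, so it does not bear on a halogen swap. Without a comparable step to lean on, the expectation is a step of no clear size in this assay, in neither direction beyond the scatter. Compound 4 is therefore estimated at 290 nM, with a range from 130 nM to 650 nM, which corresponds to an expected step of no change at the digits printed from compound 3 to compound 4 (within the scatter).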

Compound 4, half-maximal inhibitory concentration: 150 nM
The estimate for compound 4 lay 1.9-fold (0.29 log units) above the measured number, and the stated range covers the measured number.
By their numbers in this assay, from the lowest: compounds 1 and 2 (each within the scatter of the next); then compounds 4 and 3 (each within the scatter of the next).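

Among these compounds, this is the first halogen swap at this position: in this assay, bromo in place of chloro on this aromatic carbon gives a 1.9-fold lower number from compound 3 to compound 4 (0.29 log units; within the scatter) and so stays inside the normal spread of repeat measurements, which means the two halogens cannot be told apart here. The change is also unlike the one measured earlier, where cyclopropyl in place of methyl on an aromatic carbon gave a 19-fold higher number from compound 2 to compound 3 (1.29 log units; beyond the scatter) and moved the number well beyond that spread, so not every single-group change in this series has a large effect. No measurement shown here explains why this swap leaves the number within the scatter.

The compounds shown leave open whether a group of a different kind on this carbon, such as an amine, a methoxy group or a carboxylic acid, would shift the number beyond the scatter. Among the compounds shown here, they also leave open whether bromo and chloro would remain indistinguishable in compounds that carry methyl in place of cyclopropyl, since this swap is seen only with cyclopropyl present.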